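The source may hold more compounds than are shown below. What is called first, only, known or untested is meant among the compounds shown, and "the series" means these compounds.

- Compound 1 `Oc1cccc(C(c2c[nH]c3ccc(Br)cc23)c2c[nH]c3ccc(Br)cc23)c1`: 3900 nM
- Compound 2 `COc1ccc(C(c2c[nH]c3ccc(Br)cc23)c2c[nH]c3ccc(Br)cc23)cc1OC`: 6100 nM

These two compounds share a core and differ only in the aromatic group on a saturated chain carbon bound to two aromatic carbons. In a functional assay on HeLa cells (Homo sapiens) for inhibition, read by MTT assay, with a stated time of 48 h (on this read-out higher numbers stand for weaker inhibition and lower numbers for stronger inhibition), compound 2 gives 6100 nM, and compound 1 gives 3900 nM. Among the measured compounds shown here, the gap is a 1.6-fold higher number from compound 1 to compound 2 (0.19 log units; within the scatter), so compound 2 stands level with the only other measured compound.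

Compound 3 `Clc1ccc(C(c2c[nH]c3ccc(Br)cc23)c2c[nH]c3ccc(Br)cc23)cc1` has not yet been measured. It carries 4-chlorophenyl in place of 3,4-dimethoxyphenyl at that same carbon: 4-chlorophenyl in place of 3,4-dimethoxyphenyl on a saturated chain carbon bound to two aromatic carbons. For the measured compounds named here, the only measured evidence is a 1.6-fold higher number from compound 1 to compound 2 (0.19 log units; within the scatter), a change at this carbon that stays within the scatter. Going by the values given here, that single step involved a different pair of groups, and no measured compound carries a chlorophenyl group, so the data point in no clear direction. No change beyond the scatter is therefore expected, and the expected step is a 1.2-fold lower number from compound 2 to compound 3 (0.09 log units; within the scatter). In this assay, the estimate for compound 3 is 5000 nM, with an expected range of 2000 nM to 12000 nM.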

Compound 3, half-maximal inhibitory concentration: 4800 nM
Beside the measured number, compound 3's estimate is 1.0-fold (0.02 log units) above it; the range from low to high includes it.
By their numbers in this assay, from the lowest: compounds 1, 3 and 2 (each within the scatter of the next).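

Among the compounds shown here, the first measured step at this carbon could not show whether a group without oxygen would behave differently, and compound 3 now offers that test. In this assay, 4-chlorophenyl in place of 3,4-dimethoxyphenyl gives a 1.3-fold lower number from compound 2 to compound 3 (0.10 log units; within the scatter) and 4-chlorophenyl in place of 3-hydroxyphenyl gives a 1.2-fold higher number from compound 1 to compound 3 (0.09 log units; within the scatter) so neither change moves the result beyond the normal spread of repeated measurements. The first of these swaps a group of 10 heavy atoms with 2 hydrogen-bond acceptors for one of 7 heavy atoms with 0 hydrogen-bond acceptors, and among these three compounds this difference comes with no clear shift in the number, which makes the three aromatic groups indistinguishable here.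

The compounds shown leave open whether this tolerance extends to an aromatic ring carrying an amine or a carboxylic acid, or to a longer chain in place of the aromatic ring at this carbon. Nothing measured here explains why these three compounds read alike, and no supporting data bear on that question.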